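The source may report more compounds than this note shows. Statements on the series, on what has been measured and on what is new or still open speak of the compounds shown alone.

Measured compounds:
compound 1 `CC1CCN(c2c(S(=O)(=O)c3ccc(F)c(F)c3)cnc3ccc(Cl)cc23)CC1` with 72%
compound 2 `CC1CCN(c2c(S(=O)(=O)c3ccc(C#N)cc3)cnc3ccc(Cl)cc23)CC1` with 31%

Both were tested in an assay on isolated protein for displacement of a labelled ligand from metabotropic glutamate receptor 5 (Homo sapiens), with a stated time of 60 min, tested at 1 uM; on this read-out lower numbers stand for less inhibition and higher numbers for more inhibition at the one concentration tested (going by the name of the read-out). Within the data shown here, compound 2 stands lowest of the two numbers; its nearest neighbour is compound 1, and the move between them, a number 41 percentage points lower from compound 1 to compound 2 (beyond the scatter), is the only step available. That step exchanges one substituted phenyl on the sulfonyl sulfur for another, and it shows that what sits on that phenyl can shift the read-out by a large margin in this assay.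

Compound 3 `Cc1cc(C)cc(S(=O)(=O)c2cnc3ccc(Cl)cc3c2N2CCC(C)CC2)c1` is not yet measured. It differs from compound 2 in one place: 3,5-dimethylphenyl in place of 4-cyanophenyl on a sulfonyl sulfur. The change once more alters only the phenyl on the sulfonyl sulfur, so the step from compound 1 to compound 2 is the one that bears on it, and it was large. Among the measured compounds shown here, with the nitrile gone and two methyl groups entering, the author expects compound 3 to move back in the direction of compound 1, by an estimated a number 27 percentage points higher from compound 2 to compound 3 (beyond the scatter), though with no second example of this kind the size is uncertain. The expected value for compound 3 in this assay is 58%, within an estimated range from 30% to 85%.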

Compound 3, a percentage reported as inhibition, at one concentration (the size of the read-out at that concentration, not a potency): 49%
Compound 3: middle estimate off by 9 percentage points, on the high side, and the stated range covers the measured number.
By their numbers in this assay, from the lowest: compound 2; then compound 3; then compound 1.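

The second substituted phenyl on the sulfonyl sulfur places a third level in this assay, and the swap of 4-cyanophenyl for 3,5-dimethylphenyl gives a number 18 percentage points higher from compound 2 to compound 3 (beyond the scatter). Compound 3 has no nitrile, yet the exchange of 3,4-difluorophenyl for 3,5-dimethylphenyl still gives a number 23 percentage points lower from compound 1 to compound 3 (beyond the scatter), so the absence of the nitrile alone does not bring the read-out back to the level of compound 1, and among these three compounds the 3,4-difluorophenyl group stands highest, with both of its steps beyond the scatter. Nothing measured here explains why the three phenyl groups separate in this order.

Since each exchange alters all the substituents on the phenyl at once, the compounds shown cannot separate the contribution of one methyl group from that of the other, or of one fluorine from that of the other. They also leave open how a methoxy group, an amine or a carboxylic acid on that phenyl would read in this assay, and whether a plain alkyl chain on the sulfonyl sulfur could take the place of the phenyl ring.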